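Adding a chloro group to a compound at the limit

The source may report more compounds than this note shows. Statements on the series, on what has been measured and on what is new or still open speak of the compounds shown alone.

Of the compounds shown here, three sharing one core have so far been tested in a functional assay on the whole organism for antagonist activity, with Mus musculus as the target (on this read-out higher numbers stand for an effect only at larger amounts of compound and lower numbers for an effect already at smaller amounts), on mice. Compound 1 (`CSc1nc(-c2ccccc2)nn1C`) gives > 200 mg/kg as its result, which is a limit and not a number. Compound 2 (`Cn1nc(-c2ccccc2)nc1[S+](C)[O-]`) gives > 200 mg/kg as its result, again a limit. Compound 3 (`Cn1nc(-c2ccccc2)nc1S(C)(=O)=O`) gives > 200 mg/kg as its result, also only a limit. The whole set therefore stands at one place, the limit of > 200 mg/kg in this assay, at which 3 of the 3 values shown sit, and no order among the three can be read.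

Compound 4 (`Cn1nc(-c2ccc(Cl)cc2)nc1S(C)(=O)=O`) differs from compound 3 by one change (chloro in place of hydrogen on an aromatic carbon): chloro in place of hydrogen on an aromatic carbon, para to a large group. The measured steps (a step that the two limits leave unreadable from compound 1 to compound 2; a step that the two limits leave unreadable from compound 2 to compound 3; a step that the two limits leave unreadable from compound 1 to compound 3) have no readable size, and all of them alter the sulfur-bearing group rather than this position. Within the data shown here, no measured step therefore gives a size for the new change, and the expectation stays loose. The estimate can only start from compound 3 at > 200 mg/kg in this assay as a limit. The expected shift toward smaller doses is modest (an at least 1.5-fold lower number from compound 3 to compound 4 (0.18 log units; that floor lies within the scatter)) and may not appear at all. For compound 4 the estimated dose is 130 mg/kg with an expected range from 40 mg/kg to 300 mg/kg in this assay once measured.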

Compound 4, dose for half-maximal effect: > 200 mg/kg
Compound 4 gave a limit, no number (the forecaster's own chance of this, stated with the estimate: 50%); middle value at least 1.5-fold (0.18 log units) away from the limit.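

In this assay compound 4 gives > 200 mg/kg as a limit and not a number. Compound 3 also stands at a limit, so the step from compound 3 to compound 4 cannot be read, and the set stays in one place: the limit of > 200 mg/kg in this assay, at which 4 of the 4 values shown sit. The compounds shown leave open whether chloro in place of hydrogen changes the dose at all.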